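Notes on the step from compound 3 to compound 4

The compounds below may be only part of what the source reports. "The series", "measured", "known", "first", "only" and "open" are said of these compounds alone.

The series shares one core, carried by compound 1 `COc1cc2c(cc1OC)CN(S(=O)(=O)c1ccc(-n3cc(COc4ccc(C=O)cc4)nn3)cc1)CC2`, compound 2 `COc1cc2c(cc1OC)CN(S(=O)(=O)c1ccc(-n3cc(COc4ccc([N+](=O)[O-])cc4)nn3)cc1)CC2` and compound 3 `COc1cc2c(cc1OC)CN(S(=O)(=O)c1ccc(-n3cc(COc4ccccc4C)nn3)cc1)CC2`. In an ADME assay on Vero cells (Chlorocebus sabaeus) for cytotoxicity, with a stated time of 4 days (a higher number here means a weaker inhibitor, a lower number a stronger inhibitor), compound 1 gives > 50 ug/mL, a limit of the assay rather than a number. Compound 2 also reaches only a limit in this assay, at > 50 ug/mL. Compound 3 likewise stops at a limit in this assay, with > 50 ug/mL. Compound 3 therefore stands where every value shown stands, because of the limit of > 50 ug/mL in this assay, at which 3 of the 3 values shown sit. The steps among the measured compounds, a step that the two limits leave unreadable from compound 1 to compound 2, a step that the two limits leave unreadable from compound 1 to compound 3 and a step that the two limits leave unreadable from compound 2 to compound 3, cannot be sized; both ends of each sit at a limit.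

Compound 4 `COc1cc2c(cc1OC)CN(S(=O)(=O)c1ccc(-n3cc(COc4ccc(C=O)cc4OC)nn3)cc1)CC2` differs from compound 3 by 4-formyl-2-methoxyphenyl in place of 2-methylphenyl on an oxygen on a saturated carbon. Two of the measured steps touch the same place on the oxygen on a saturated carbon, the changes from compound 1 to compound 3 and from compound 2 to compound 3, and neither yields a readable size; the formyl group that enters was already present in compound 1. No step beyond the scatter is therefore expected in this assay, and the step from compound 3 to compound 4 is estimated as a number no higher from compound 3 to compound 4 (the limit leaves the size open). Compound 4 is expected to give 50 ug/mL in this assay, within 25 ug/mL to 100 ug/mL, and most likely to reach only the limit again.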

Compound 4, half-maximal inhibitory concentration: > 50 ug/mL
Compound 4: only a limit was reported; the forecaster's own chance of this, stated with the estimate: 85%; the middle value lies on the limit itself.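

Compound 4 adds no readable step to compound 1, compound 2 or compound 3 in this assay, because each pair ends at the same assay limit: the limit of > 50 ug/mL in this assay, at which 4 of the 4 values shown sit.

The compounds shown leave open how far any of the four lies from that limit, and whether the methoxy or any other change on the shared core alters the read-out at all.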